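A few compounds are considered here, and "the series" means these few. Any claim that something is new, unique, unknown or untested is made for them only; others in the source may bear on it.

Measured compounds:
compound 1 `CCNC(=O)Nc1ccc(S(=O)(=O)Oc2ccccc2C)cc1` gives 12000 nM in a functional assay on HT-29 cells (Homo sapiens) for cytotoxicity, read by sulforhodamine B assay, with a stated time of 48 h; a lower number here means a stronger inhibitor, a higher number a weaker inhibitor;
compound 2 `CCNC(=O)Nc1ccc(S(=O)(=O)Oc2ccccc2CC)cc1` gives 12000 nM in this assay.

Compound 2 stands level with compound 1, since the step of no change at the digits printed from compound 1 to compound 2 (within the scatter) lies within the scatter. Compound 3 `CCNC(=O)Nc1ccc(S(=O)(=O)Oc2ccc(O)cc2)cc1` is not yet measured. It differs from compound 2 by 4-hydroxyphenyl in place of 2-ethylphenyl on an oxygen. Within the data shown here, the only measured step swaps a methyl for a hydrogen on that same side group and leaves potency unchanged, so there is no measured step that directly bears on trading an ethyl for a hydroxyl. With nothing pointing either way, the expected step of no change at the digits printed from compound 2 to compound 3 (within the scatter) is none beyond the scatter. Compound 3 is therefore estimated at 12000 nM, between 4000 nM and 36000 nM.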

Compound 3, half-maximal inhibitory concentration: 12000 nM
Compound 3: the middle estimate sits on the measured number at the digits printed, within the range that was stated.
By their numbers in this assay, from the lowest: compounds 1, 2 and 3 (each within the scatter of the next).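

In this assay, among these compounds, the earlier compounds differed only by a small alkyl group on the ring. Changing the ring group itself on the oxygen bound to the sulfonyl sulfur, 4-hydroxyphenyl in place of 2-ethylphenyl gives no change at the digits printed from compound 2 to compound 3 (within the scatter) and 4-hydroxyphenyl in place of 2-methylphenyl gives no change at the digits printed from compound 1 to compound 3 (within the scatter), so a ring carrying a hydroxyl, with its hydrogen-bond donor, is tolerated here as well as one carrying an alkyl group. No supporting evidence is available to explain this result. On these data alone, whether an amine, a carboxylic acid or a longer chain on this ring would shift the value remains open.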